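This account rests on a few compounds, and the source may have more. Where it says the series, first, only, none or still open, it means among the compounds named here.

Measured so far in an in vitro functional assay on HEK285-7 cells for antagonist activity at prostaglandin D2 receptor 2 (Homo sapiens), read by BRET and beta-arrestin recruitment; on this read-out higher numbers stand for larger maximal responses and lower numbers for smaller maximal responses:
compound 1 `COc1cc(-c2nc(C(c3ccc(F)cc3)c3ccc(F)cc3)sc2CC(=O)O)ccn1` gives 60%
compound 2 `O=C(O)Cc1sc(C(Cc2ccccc2)c2ccccc2)nc1-c1ccc(Cl)cc1` gives 50%

Compound 1 and compound 2 lie within the usual scatter of each other, so no ranking follows from these two numbers. Compound 3 `CN(C)c1cc(-c2nc(C(c3ccc(F)cc3)c3ccc(F)cc3)sc2CC(=O)O)ccn1` is not yet measured. It differs from compound 1 in one place: dimethylamino in place of methoxy on an aromatic carbon. Among the compounds with values here, no measured pair shows this change, so its effect is unknown. Given two compounds that agree within scatter, a step of no more than the scatter is expected in this assay, in either direction. The expected step of no change at the digits printed from compound 1 to compound 3 (within the scatter) is near zero. For compound 3 the estimate is 60%, range 40% to 80%.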

Compound 3, largest response reached (reported as efficacy), in percent of the reference or control that the assay uses: 80%
The estimate for compound 3 lay 20 percentage points below the measured number; the range from low to high includes it.
By their numbers in this assay, from the lowest: compounds 2 and 1 (each within the scatter of the next); then compound 3.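

In this assay, dimethylamino in place of methoxy on the aromatic carbon next to the ring nitrogen gives a number 20 percentage points higher from compound 1 to compound 3 (beyond the scatter). Within the data shown here, this is the first step beyond the usual scatter, and it shows that the response depends on the group at this position. Nothing on hand bears on what lies behind this step.

On these data alone, the step rests on a single pair, so whether it holds with other substituents on the shared core remains open. As far as these compounds go, how a primary amine or a pyrrolidine would read at this carbon also remains open.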